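Furan-to-chlorophenyl swap on the cinnamamide arm

The compounds below may be only part of what the source reports. "The series", "measured", "known", "first", "only" and "open" are said of these compounds alone.

Within the series, compound 2 `O=C(/C=C/c1ccco1)NCCNc1ccnc2cc(Cl)ccc12` stands at the top of the numbers: in an ADME assay on Vero cells (Chlorocebus sabaeus) for cytotoxicity, read by MTT assay, with a stated time of 72 h (on this read-out lower numbers stand for higher toxicity in this test and higher numbers for lower toxicity in this test), compound 2 gives 629000 nM. Compound 1 `COc1cc(OC)c(OC)cc1/C=C/C(=O)NCCNc1ccnc2cc(Cl)ccc12` gives 16100 nM, and compound 3 `COc1ccc(/C=C/C(=O)c2ccccc2OCC(=O)NCCNc2ccnc3cc(Cl)ccc23)cc1OC` gives 5310 nM, both well beyond the scatter from compound 2. Compound 4 `O=C(/C=C/c1ccc(Cl)cc1)NCCNc1ccnc2cc(Cl)ccc12` differs from compound 2 in one place (4-chlorophenyl in place of furan-2-yl on a double-bonded chain carbon bound to a double-bonded chain carbon). Among the measured compounds shown here, no measured pair in the set isolates this exchange, so the direction rests on the other two numbers. Because compound 1 gives 16100 nM and compound 3 gives 5310 nM, the step from compound 2 to compound 4 is expected to run toward lower numbers, of the order a 10-fold lower number from compound 2 to compound 4 (1.02 log units; beyond the scatter). For compound 4 the estimated value in this assay is 60000 nM, in the range 10000 nM to 300000 nM.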

Compound 4, half-maximal cytotoxic concentration: 6930 nM
Beside the measured number, compound 4's estimate is 8.7-fold (0.94 log units) above it, and the stated range ends above it.
By their numbers in this assay, from the lowest: compounds 3 and 4 (each within the scatter of the next); then compound 1; then compound 2.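

On the double-bonded chain carbon bound to a double-bonded chain carbon, the exchange of furan-2-yl for 4-chlorophenyl gives a large step in this assay, a 91-fold lower number from compound 2 to compound 4 (1.96 log units; beyond the scatter). Among the compounds shown here, this pair differs in one place, so the high number of compound 2 can now be tied to this exchange, which the earlier compounds could not show. The data at hand offer no explanation for the size of this step.

Still open, on these data alone, is how much of the step belongs to the ring and how much to the chlorine. A plain phenyl or a thiophene at this place would separate the two.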